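Taking away the last methoxy group

The compounds below may be only part of what the source reports. "The series", "measured", "known", "first", "only" and "open" are said of these compounds alone.

Measured in a functional assay on L1210 cells (Mus musculus) for antiproliferative activity, read by cell counting, with a stated time of 2 days; a higher number here means a weaker inhibitor, a lower number a stronger inhibitor:
compound 1 `CCN(CC)c1nc(N)c(C(=O)c2cc(OC)c(OC)c(OC)c2)s1`: 62000 nM
compound 2 `COc1ccc(C(=O)c2sc(N3CCCC3)nc2N)cc1OC`: 60000 nM
compound 3 `COc1cccc(C(=O)c2sc(N3CCCC3)nc2N)c1`: > 200000 nM, a limit and not a number

Compound 3 stands at the limit of > 200000 nM in this assay, at which 1 of the 3 values shown sits. Its true place on the scale is therefore not known as a number, and it can be read only as a limit.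

Compound 4 `Nc1nc(N2CCCC2)sc1C(=O)c1ccccc1` differs from compound 3 by a single change, (hydrogen in place of methoxy on an aromatic carbon). This is hydrogen in place of methoxy on an aromatic carbon, meta to a large group, and it leaves the aromatic ring with no methoxy at all.

Within the data shown here, one measured step bears on this change, since the same swap, at another methoxy group, has been seen once: an at least 3.3-fold higher number from compound 2 to compound 3 (0.52 log units; beyond the scatter). One step is thin evidence, yet it points in a clear direction, towards a higher number and so a weaker inhibitor. Because of an at least 3.3-fold higher number from compound 2 to compound 3 (0.52 log units; beyond the scatter) the expectation for compound 4 is a further move the same way, and this assay may well report only a limit again. The expected step is a step that the limit leaves unreadable from compound 3 to compound 4. For compound 4 the estimate is 250000 nM, with an expected range from 100000 nM to 600000 nM.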

Compound 4, half-maximal inhibitory concentration: > 200000 nM
Compound 4: no number, only a limit; the forecaster's own chance of this, stated with the estimate: 65%; the middle value lies beyond the limit too.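

In this assay compound 4 gives > 200000 nM as a limit and not a number. Compound 3 also stands only as a limit, so the step between compound 3 and compound 4 cannot be read. The compounds shown leave open whether removing this last methoxy group changes the antiproliferative activity at all, and in which direction.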